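Esterifying the hydroxymethyl of compound 1

A few compounds are considered here, and "the series" means these few. Any claim that something is new, unique, unknown or untested is made for them only; others in the source may bear on it.

Compound 1 `Cc1nc2c(OCc3ccccc3)cccn2c1CO` and compound 2 `COCc1c(C)nc2c(OCc3ccccc3)cccn12` share one core. In a functional assay on the whole organism with Rattus norvegicus as the target, with a stated time of 4 h, at a dose of 40 mg/kg by the intraperitoneal route (on this read-out higher numbers stand for more inhibition at the one dose given (going by the name of the read-out) and lower numbers for less inhibition), compound 1 gives 99% and compound 2 gives 99%; the step of no change at the digits printed from compound 1 to compound 2 (within the scatter) lies within the scatter. Compound 3 `Cc1nc2c(OCc3ccccc3)cccn2c1COC(=O)C(C)(C)C` differs from compound 1 by (tert-butyl)carbonyl in place of hydrogen on an oxygen on a saturated carbon. For the measured compounds named here, the single step at the same oxygen, no change at the digits printed from compound 1 to compound 2 (within the scatter), bears on this change and showed no shift. Compound 3 is therefore expected to stay level with compound 1, with a number 2 percentage points lower from compound 1 to compound 3 (within the scatter) expected to be no step beyond the scatter. Compound 3 is estimated at 97%, between 88% and 100%.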

Compound 3, a percentage reported as inhibition, in the whole organism at one dose (the size of the read-out at that dose, not a potency): 48%
Compound 3: middle estimate off by 49 percentage points, on the high side; measured number outside the range, below it.
By their numbers in this assay, from the lowest: compound 3; then compounds 1 and 2 (each within the scatter of the next).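

In this assay the oxygen on the saturated carbon proves sensitive to what it carries, which the hydrogen and methyl pair did not reveal: (tert-butyl)carbonyl in place of hydrogen gives a number 51 percentage points lower from compound 1 to compound 3 (beyond the scatter) and (tert-butyl)carbonyl in place of methyl gives a number 51 percentage points lower from compound 2 to compound 3 (beyond the scatter). This position therefore accepts methyl, but not every group. No measurement available here accounts for the drop.

On these data alone, whether the drop goes with the carbonyl or with the tert-butyl stays open. Acetyl or a longer alkyl chain on the same oxygen would separate the two.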